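Replacing the Chlorophenoxy Group With a Naphthyl Ring

The compounds below may be only part of what the source reports. "The series", "measured", "known", "first", "only" and "open" are said of these compounds alone.

Of the compounds shown here, three sharing one core have been measured in an ADME assay for permeability, using PAMPA, with a stated time of 30 min, at pH 7.4; on this read-out higher numbers stand for higher permeability and lower numbers for lower permeability. Compound 1 `COc1cccc(Oc2ccc3c(NCCCNCc4ccco4)ccnc3c2)c1` gives 317 10^-6 cm/s, compound 2 `CC(C)CCc1ccc2c(NCCCNCc3ccco3)ccnc2c1` gives 23 10^-6 cm/s, and compound 3 `Clc1ccc(Oc2ccc3c(NCCCNCc4ccco4)ccnc3c2)cc1` gives 317 10^-6 cm/s. Compound 3 thus stands level with compound 1, the two together at the top of the three. Swapping one aryl group for another on the oxygen gave no change at the digits printed from compound 1 to compound 3 (within the scatter). Compound 4 `c1coc(CNCCCNc2ccnc3cc(-c4cccc5ccccc45)ccc23)c1` differs from compound 3 by naphthalen-1-yl in place of 4-chlorophenoxy on an aromatic carbon. Within the data shown here, no measured step removes the oxygen-linked group entirely in favour of a carbon-linked ring system; the nearest guide is a 14-fold higher number from compound 2 to compound 3 (1.14 log units; beyond the scatter), where a carbon-linked group occupied that place. A drop beyond the scatter, though smaller than that one, is therefore expected, a 2.6-fold lower number from compound 3 to compound 4 (0.42 log units; beyond the scatter). Compound 4 is expected to give 120 10^-6 cm/s, within a range of 35 10^-6 cm/s to 400 10^-6 cm/s.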

Compound 4, apparent permeability: 237 10^-6 cm/s
For compound 4 the middle estimate is 2.0-fold (0.30 log units) below the measured one; the range from low to high includes it.
By their numbers in this assay, from the lowest: compound 2; then compounds 4, 1 and 3 (each within the scatter of the next).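

At this aromatic carbon, the oxygen link is not required for a high number in this assay: naphthalen-1-yl, attached directly through carbon, matches both aryl ethers (a 1.3-fold lower number from compound 3 to compound 4 (0.13 log units; within the scatter); a 1.3-fold lower number from compound 1 to compound 4 (0.13 log units; within the scatter)). Compound 2, with isopentyl, is the only one of the four without an aromatic ring at this place, and it stands well apart (a 10-fold higher number from compound 2 to compound 4 (1.01 log units; beyond the scatter)). Nothing shown explains these differences.

As far as these compounds go, what a plain phenyl group or a carboxylic acid at this aromatic carbon would give remains open. So does whether a longer chain than isopentyl would stay as low as compound 2.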